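Acetamido in place of a hydroxymethyl carboxamide

A few compounds are considered here, and "the series" means these few. Any claim that something is new, unique, unknown or untested is made for them only; others in the source may bear on it.

This account follows one change on the shared core of compound 1 `Cn1nc(-c2ccc(C(=O)NC(C)(C)CO)cc2)s/c1=N\C1CCCC(O)C1`. In an in vivo ADME assay on the whole organism (Eutheria) for pharmacokinetics (on this read-out lower numbers stand for lower oral bioavailability and higher numbers for higher oral bioavailability), compound 1 gives 63%, the only single-number result shown here. Its companion compound 2 `Cn1nc(-c2ccc(C(N)=O)cc2)s/c1=N\C1CCCC(O)C1` has been run more than once: in this assay compound 2 gives 61.2%; 38.5% (2 entries), and the several entries of compound 2 in this assay, 61.2%; 38.5% (2 entries) shows how far two runs of one compound can sit apart. Within the data shown here, no step between two measured compounds is available, so the size of a structural change cannot be read from the data at hand.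

The new compound 3 `CC(=O)Nc1ccc(-c2nn(C)/c(=N/C3CCCC(O)C3)s2)cc1` differs from compound 1 in one place: acetamido in place of (1-(hydroxymethyl)-1-methylethyl)carbamoyl on an aromatic carbon. Among the measured compounds shown here, no measured pair tells what such an exchange does, and the two entries of compound 2 in this assay warn that a single number may land on either side of any guess. The step of a number 13 percentage points lower from compound 1 to compound 3 (beyond the scatter) is expected to be a modest fall, close to the usual scatter. Compound 3 is therefore estimated at 50% in this assay, with a range from 25% to 78%.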

Compound 3, oral bioavailability in the Eutheria assay: 76%
Compound 3: middle estimate off by 26 percentage points, on the low side; the range from low to high includes it.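

Exchanging the (1-(hydroxymethyl)-1-methylethyl)carbamoyl for acetamido, on an aromatic carbon para to a large group, did not lower the read-out: in the Eutheria assay the change gives a number 13 percentage points higher from compound 1 to compound 3 (beyond the scatter). In a physicochemical assay for solubility, at pH 7.4 (on this read-out lower numbers stand for lower solubility and higher numbers for higher solubility), compound 1 gives 58 ug/mL and compound 3 gives 350 ug/mL, so the same exchange also brings a 6.0-fold higher number from compound 1 to compound 3 (0.78 log units; beyond the scatter). This position therefore accepts a group with fewer heavy atoms while both read-outs rise, though the single number for compound 3 in the Eutheria assay has to be weighed against how far repeated runs of one compound can sit apart: the several entries of compound 2 in the Eutheria assay, 61.2%; 38.5% (2 entries)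

What the compounds shown leave open is whether a carboxylic acid, an amine or a longer acyl chain on this aromatic carbon would keep both read-outs at the level of compound 3. They also cannot tell whether the rise in solubility and the rise in oral bioavailability are linked, as one pair of compounds gives two steps in the same direction and nothing more.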